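This account rests on a few compounds, and the source may have more. Where it says the series, first, only, none or still open, it means among the compounds named here.

Values in an ADME assay on L929 cells (Mus musculus) for cytotoxicity, read by resazurin assay, with a stated time of 72 h (on this read-out higher numbers stand for weaker inhibition and lower numbers for stronger inhibition), each one a limit and not a number:

- Compound 1 `O=C(/C=C/c1ccc2c(c1)B(O)OC2)c1ccc(C(F)(F)F)cc1`: > 10 ug/mL
- Compound 2 `O=C(/C=C/c1ccc2c(c1)B(O)OC2)c1ccc([N+](=O)[O-])cc1`: > 10 ug/mL
- Compound 3 `O=C(O)c1ccc(C(=O)/C=C/c2ccc3c(c2)B(O)OC3)cc1`: > 10 ug/mL

Compound 3 stands only at a limit, > 10 ug/mL, so it has no exact place in the series. The measured set offers only (the limit of > 10 ug/mL in this assay, at which 3 of the 3 values shown sit). None of the three compounds can therefore be ranked against the others.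

The next structure is compound 4 `O=C(/C=C/c1ccc2c(c1)B(O)OC2)c1ccc(-c2ccccc2)cc1`, which has phenyl in place of carboxy on an aromatic carbon, para to a large group: phenyl in place of carboxy on an aromatic carbon.

Going by the values given here, three measured steps bear on this change: a step that the two limits leave unreadable from compound 1 to compound 2, a step that the two limits leave unreadable from compound 1 to compound 3 and a step that the two limits leave unreadable from compound 2 to compound 3. None of them gives a size or a direction, and none of them brings in phenyl. The series thus supplies no ground for expecting a shift in this assay beyond the scatter, in either direction. The expected step is a step that the limit leaves unreadable from compound 3 to compound 4, and a further report of a limit is expected as the likeliest outcome. If a number is reported, the estimate stays close to the limit shared by the series, with a wide range to reflect how little the steps show. For compound 4 the estimated value is 12 ug/mL, with an expected range from 4 ug/mL to 40 ug/mL.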

Compound 4, half-maximal inhibitory concentration: > 10 ug/mL
Compound 4: a limit, no number; the forecaster's own chance of this, stated with the estimate: 70%; the middle value lies beyond the limit too.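

In this assay compound 4 gives > 10 ug/mL, a limit and not a number. The steps to compound 4 from compound 1, compound 2 and compound 3 therefore cannot be read, and the series stays at one limit: the limit of > 10 ug/mL in this assay, at which 4 of the 4 values shown sit.

The compounds shown leave open how far any of the four lies past that limit, and whether trifluoromethyl, nitro, carboxy or phenyl makes any difference in this assay.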